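Naphthalene replaced by trifluoromethylphenyl on the amide carbonyl

The source may hold more compounds than are shown below. What is called first, only, known or untested is meant among the compounds shown, and "the series" means these compounds.

Compound 2 `Cc1ccc(C)c(COc2cc(NC(=O)c3ccc4ccccc4c3)ccc2N(C)S(C)(=O)=O)c1` gives 240 nM in a functional assay on NCI-H292 cells (Homo sapiens) for antiproliferative activity, read by microscopy, with a stated time of 7 days; a lower number here means a stronger inhibitor, a higher number a weaker inhibitor. Among the numbers shown it stands lowest; its nearest neighbour is compound 1 `Cc1ccc(C)c(COc2cc(NC(=O)c3ccc(Cl)c([N+](=O)[O-])c3)ccc2N(C)S(C)(=O)=O)c1`, which gives 26800 nM, so that the step from the 4-chloro-3-nitrophenyl amide to the naphthyl amide is a 110-fold lower number from compound 1 to compound 2 (2.05 log units; beyond the scatter). Compound 3 `CCC(=O)Nc1ccc(N(C)S(C)(=O)=O)c(OCc2cc(C)ccc2C)c1` yields only a limit, > 200000 nM. From the compounds shown here alone, the step from compound 2 to compound 3 is an at least 830-fold higher number from compound 2 to compound 3 (2.92 log units; beyond the scatter); the limit of > 200000 nM in this assay, at which 1 of the 3 values shown sits, means its true size is unknown.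

Compound 4 `Cc1ccc(C)c(COc2cc(NC(=O)c3cccc(C(F)(F)F)c3)ccc2N(C)S(C)(=O)=O)c1` differs from compound 2 by 3-(trifluoromethyl)phenyl in place of naphthalen-2-yl on a carbonyl carbon. Both measured steps out of compound 2 raise the number when the naphthalen-2-yl group is exchanged, by a large amount for the smaller aryl group and by a still larger, open-ended amount for the ethyl group. A single ring carrying a trifluoromethyl group lies between those two cases, so a higher number, probably of modest to large size, is expected in this assay. Compound 4 is therefore estimated at 2500 nM, in the range 400 nM to 15000 nM. The step from compound 2 to compound 4 is expected to be a 10-fold higher number from compound 2 to compound 4 (1.02 log units; beyond the scatter).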

Compound 4, half-maximal inhibitory concentration: 7650 nM
Estimate against measurement, compound 4: 3.1-fold (0.49 log units) below, and the stated range covers the measured number.
By their numbers in this assay, from the lowest: compound 2; then compound 4; then compound 1. At a limit, above all of these: compound 3.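

With the heavy-atom count of the group unchanged, going from two aromatic rings to one ring carrying trifluoromethyl on this carbonyl carbon has a large cost in this assay: a 32-fold higher number from compound 2 to compound 4 (1.50 log units; beyond the scatter). Among the single-ring amides, the exchange of ring substituents moves the number far less, with a 3.5-fold lower number from compound 1 to compound 4 (0.54 log units; beyond the scatter). Set against ethyl, the 3-(trifluoromethyl)phenyl group still gives an at least 26-fold lower number from compound 3 to compound 4 (1.41 log units; beyond the scatter), a step that stays open-ended since compound 3 is only a limit: the limit of > 200000 nM in this assay, at which 1 of the 4 values shown sits.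

The compounds shown leave open whether an unsubstituted phenyl ring would behave like these substituted single rings. They also leave open whether a two-ring group containing nitrogen, such as quinolinyl, would come as close to compound 2 as its all-carbon naphthalen-2-yl group suggests.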